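Aryl extension of a benzimidazole hydroxamic acid

The compounds below may be only part of what the source reports. "The series", "measured", "known", "first", "only" and "open" are said of these compounds alone.

Measured compounds:
compound 1, `O=C(CCCCCCc1nc2ccccc2[nH]1)NO`, 2700 nM
compound 2, `O=C(CCCCCCc1nc2ccc(F)cc2[nH]1)NO`, 1900 nM

In a functional assay on SK-OV-3 cells (Homo sapiens) for cytotoxicity (on this read-out lower numbers stand for stronger inhibition and higher numbers for weaker inhibition), compound 1 gives 2700 nM, the highest of the two numbers measured, and its nearest neighbour is compound 2, which sits a 1.4-fold lower number from compound 1 to compound 2 (0.15 log units; within the scatter). Compound 3, `CN(C)c1ccc(-c2ccc3nc(CCCCCCC(=O)NO)[nH]c3c2)cc1`, has not yet been measured in this assay. Relative to compound 1 it carries 4-(dimethylamino)phenyl in place of hydrogen on an aromatic carbon. Among the measured compounds shown here, no measured step touches the same position or the same kind of change: the only step available, fluoro in place of hydrogen on an aromatic carbon, is a 1.4-fold lower number from compound 1 to compound 2 (0.15 log units; within the scatter), and it tells nothing about a 4-(dimethylamino)phenyl entering on the fused ring. The expectation for compound 3 therefore rests on compound 1 alone, with a wide range to allow for a change in either direction; the estimated step is a 1.8-fold lower number from compound 1 to compound 3 (0.26 log units; within the scatter). Compound 3 is expected to give about 1500 nM, estimated to lie between 400 nM and 6000 nM.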

Compound 3, half-maximal inhibitory concentration: 6600 nM
For compound 3 the middle estimate is 4.4-fold (0.64 log units) below the measured one; measured number outside the range, above it.
By their numbers in this assay, from the lowest: compounds 2 and 1 (each within the scatter of the next); then compound 3.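

Placing 4-(dimethylamino)phenyl, with its 9 heavy atoms, on this aromatic carbon raises the number in this assay (a 2.4-fold higher number from compound 1 to compound 3 (0.39 log units; beyond the scatter)), which the fluoro step could not have shown, as it stayed within the scatter. Set against the fluoro on the same carbon, the new group gives a larger step (a 3.5-fold higher number from compound 2 to compound 3 (0.54 log units; beyond the scatter)), so this position does respond to substitution, and an aryl group here weakens inhibition modestly without abolishing it. No measured evidence bears on why this happens.

A plain phenyl or a 4-methoxyphenyl on this carbon would separate the contribution of the ring from that of its dimethylamino group. As far as these compounds go, whether a carboxylic acid on that ring, or a longer chain leading to the hydroxamic acid, would shift the number remains open.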